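Ring-nitrogen aryl swaps and Vero cell tolerance

This account rests on a few compounds, and the source may have more. Where it says the series, first, only, none or still open, it means among the compounds named here.

Compound 1 `O=C(O)c1cccc(-c2ccc(/C=C3\S/C(=N\c4ccccc4)N(c4ccc(F)cc4)C3=O)s2)c1` carries a 4-fluorophenyl on the amide-type nitrogen of its five-membered ring. In an ADME assay on Vero cells (Chlorocebus sabaeus) for cytotoxicity (a lower number here means that less compound is tolerated, a higher number that more compound is tolerated), compound 1 gives > 200000 nM, which is a limit of the assay and not a number. Compound 2 `O=C(O)c1cccc(-c2ccc(/C=C3\S/C(=N\c4ccccc4)N(c4ccc(F)cn4)C3=O)s2)c1` carries 5-fluoropyridin-2-yl in place of that group. In this assay compound 2 gives > 200000 nM, again a limit of the assay. The step that the two limits leave unreadable from compound 1 to compound 2 therefore cannot be read; all that is seen is the limit of > 200000 nM in this assay, at which 2 of the 2 values shown sit. Compound 2 thus stands only at a limit, with no measured number of its own.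

Compound 3 `O=C(O)c1cccc(-c2ccc(/C=C3\S/C(=N\c4ccccc4)N(c4cccnc4Cl)C3=O)s2)c1` differs from compound 2 by 2-chloropyridin-3-yl in place of 5-fluoropyridin-2-yl on an amide-type nitrogen in a ring. For the measured compounds named here, the only measured step bearing on this position, a step that the two limits leave unreadable from compound 1 to compound 2, is unreadable in size, so it gives no direction for a change on swapping one pyridyl for another. The expectation for compound 3 in this assay is that it also sits at the limit, estimated at 200000 nM with a range from 100000 nM to 400000 nM. The step of a number no higher from compound 2 to compound 3 (the limit leaves the size open) is expected to be none beyond the scatter.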

Compound 3, half-maximal cytotoxic concentration: > 200000 nM
Compound 3: only a limit was reported; the forecaster's own chance of this, stated with the estimate: 75%; the middle value lies on the limit itself.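

In this assay compound 3 gives > 200000 nM, a limit of the assay and not a number. No new step can be read among compound 1, compound 2 and compound 3, which share one limit: the limit of > 200000 nM in this assay, at which 3 of the 3 values shown sit.

Still open, from the compounds shown here alone, is whether any group on this amide-type nitrogen in a ring would give a measured number in this assay.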